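The compounds below may be only part of what the source reports. "The series", "measured", "known", "first", "only" and "open" are said of these compounds alone.

Measured in a physicochemical assay for solubility, in phosphate buffer, measured as kinetic solubility, at pH 7.4, tested at 250 uM; a lower number here means a less soluble compound, a higher number a more soluble compound:
- compound 1 `CCCCCCCCNc1ccc([N+](=O)[O-])cc1S(N)(=O)=O`: < 1000 nM
- compound 2 `CCCCCCCCNc1ccc(C(=O)O)cc1S(N)(=O)=O`: > 250000 nM

Compound 1 gives < 1000 nM, which is a limit of this assay and not a number. Compound 2 stands at > 250000 nM, which is also a limit and not a number. Going by the values given here, only one measured step connects these compounds: carboxy in place of nitro on an aromatic carbon gives an at least 250-fold higher number from compound 1 to compound 2 (2.39 log units; beyond the scatter).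

The next compound, compound 3 `CCCCCCCCNc1ccc(C(=O)O)cc1S(=O)(=O)NC`, has not yet been measured. It carries methyl in place of hydrogen on a sulfonamide nitrogen. Among the compounds with values here, no measured step touches that nitrogen, so the data give no direct measure of this change. Within the data shown here, the one measured step bears on it only indirectly: compound 3 keeps the carboxy group introduced in an at least 250-fold higher number from compound 1 to compound 2 (2.39 log units; beyond the scatter). A step far smaller than that one is therefore expected, leaning towards a lower number or staying within the scatter. The expected change is an at least 1.2-fold lower number from compound 2 to compound 3 (0.09 log units; that floor lies within the scatter). For compound 3, the estimated value is 200000 nM, with an expected range from 80000 nM to 300000 nM.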

Compound 3, solubility: 53000 nM
Beside the measured number, compound 3's estimate is 3.8-fold (0.58 log units) above it, outside the stated range (below it).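

Going by these compounds alone, compound 3 is the first compound here whose result is a number and not a limit: in this assay compound 3 gives 53000 nM. Within the data shown here, it also gives the first reading at the sulfonamide nitrogen, where methyl in place of hydrogen, with the carboxy group kept, gives an at least 4.7-fold lower number from compound 2 to compound 3 (0.67 log units; beyond the scatter), so a change of one heavy atom at this position is enough to move the number beyond the scatter. That step is a floor and not a full size, as compound 2 stands at a limit of the assay: the limit of > 250000 nM in this assay, at which 1 of the 3 values shown sits.

The compounds shown leave open how the number would read with a larger group on this nitrogen, such as ethyl, or with a second methyl there, and whether the step would be the same with nitro in place of the carboxy group. They also leave open what an amide or an amine in place of the carboxy group, or a shorter chain on the other amino nitrogen, would do to the number in this assay.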